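The compounds below may be only part of what the source reports. "The series", "measured", "known", "first", "only" and "open" are said of these compounds alone.

Measured so far:
- compound 1, `CCc1cc(C(C)=O)c(O)cc1OCCCC(C)(C)c1nnn[nH]1`, in an assay on isolated protein for inhibition of leukotriene B4 receptor 1 (Homo sapiens), tested at 10 uM (on this read-out higher numbers stand for more inhibition at the one concentration tested (going by the name of the read-out) and lower numbers for less inhibition), gives 100%
- compound 2, `CCc1cc(C(C)=O)c(O)cc1OCCCCCCSC`, in this assay gives 71%

Of the two numbers, compound 2 stands lowest; its nearest neighbour is compound 1, and the step of a number 29 percentage points lower from compound 1 to compound 2 (beyond the scatter) lies beyond the scatter. The unmeasured compound 3, `CCc1cc(C(C)=O)c(O)cc1OCCCCc1nnn[nH]1`, differs from compound 2 in one place: 1H-tetrazol-5-yl in place of 2-(methylsulfanyl)ethyl on a saturated chain carbon, four bonds along the chain from an oxygen on an aromatic ring. For the measured compounds named here, the only measured step that bears on this change is the one from compound 1 to compound 2, in which the tetrazole-bearing group gave way to a methylsulfanyl chain and the read-out in this assay fell by a number 29 percentage points lower from compound 1 to compound 2 (beyond the scatter). Compound 3 brings a 1H-tetrazol-5-yl back onto the chain, so a gain of roughly that size is expected, a number 19 percentage points higher from compound 2 to compound 3 (beyond the scatter), though compound 3 lacks the two methyl groups of compound 1 and its number may not climb all the way back. Compound 3 is therefore estimated at 90%, within 70% to 100%.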

Compound 3, a percentage reported as inhibition, at one concentration (the size of the read-out at that concentration, not a potency): 49%
Estimate against measurement, compound 3: 41 percentage points above; measured number outside the range, below it.
By their numbers in this assay, from the lowest: compound 3; then compound 2; then compound 1.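

In this assay the 1H-tetrazol-5-yl does not carry the read-out by itself: put in place of 2-(methylsulfanyl)ethyl, it gives a number 22 percentage points lower from compound 2 to compound 3 (beyond the scatter), so the earlier fall on leaving the tetrazole-bearing group cannot be read as a gain from the tetrazole alone. With the tetrazole kept, (1H-tetrazol-5-yl)methyl in place of 1-(1H-tetrazol-5-yl)-1-methylethyl gives a number 51 percentage points lower from compound 1 to compound 3 (beyond the scatter), the larger step, which shows that the two methyl groups on the chain carbon matter a great deal at this place. Nothing measured here explains why either step falls as it does.

Going by these compounds, it remains open whether a single methyl group on that chain carbon would recover part of the number. Also open, on these data alone, is how a carboxylic acid in place of the tetrazole, or a longer chain leading to it, would read.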